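Chloro for Hydrogen on the Phenyl Group: Estimating Compound 4

The compounds below may be only part of what the source reports. "The series", "measured", "known", "first", "only" and "open" are said of these compounds alone.

Three compounds have been measured in a functional assay on DU-145 cells (Homo sapiens) for cytotoxicity, read by MTT assay, with a stated time of 48 h; a higher number here means a weaker inhibitor, a lower number a stronger inhibitor:

Compound 1, `CCOC(=O)c1c(-c2c(Cl)c3ccccc3oc2=O)nn(-c2ccccc2)c1C(=O)OCC`, gives 48000 nM.
Compound 2, `CCOC(=O)c1c(-c2c(Cl)c3ccccc3oc2=O)nn(-c2cccc(Cl)c2)c1C(=O)OCC`, gives 24000 nM.
Compound 3, `COC(=O)c1c(-c2cc3ccccc3oc2=O)nn(-c2ccccc2)c1C(=O)OC`, gives 30000 nM.

Compound 3 stands second highest of the three numbers. Its nearest neighbour is compound 2 and its furthest is compound 1, and both of these gaps lie within the scatter, so no order among the three can be claimed.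

Compound 4, `COC(=O)c1c(-c2cc3ccccc3oc2=O)nn(-c2cccc(Cl)c2)c1C(=O)OC`, has not yet been measured. It differs from compound 3 by chloro in place of hydrogen on an aromatic carbon. Going by the values given here, one measured step bears directly on this exchange, the same replacement on the same ring in the pair sharing the ethyl esters: a 2.0-fold lower number from compound 1 to compound 2 (0.30 log units; within the scatter). That step stayed within the scatter, so the corresponding step is expected to be of similar size and direction, a 1.7-fold lower number from compound 3 to compound 4 (0.22 log units; within the scatter), a somewhat lower number without clear separation from the scatter. For compound 4 the expected value in this assay is therefore 18000 nM, with a range from 8000 nM to 40000 nM.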

Compound 4, half-maximal inhibitory concentration: 32000 nM
Beside the measured number, compound 4's estimate is 1.8-fold (0.25 log units) below it; measured number inside the range.
By their numbers in this assay, from the lowest: compounds 2, 3, 4 and 1 (each within the scatter of the next).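

In this assay the change from phenyl to 3-chlorophenyl, read on a second core, gives a 1.1-fold higher number from compound 3 to compound 4 (0.03 log units; within the scatter). This position now has two readings of chloro in place of hydrogen, neither of which leaves the scatter, and the two readings do not differ from each other beyond it: the same change on two cores in this assay, a 2.0-fold lower number (0.30 log units; within the scatter) from compound 1 to compound 2 and a 1.1-fold higher number (0.03 log units; within the scatter) from compound 3 to compound 4, 2.1-fold (0.33 log units) apart, within the scatter of two such steps. The lower number seen with the first pair therefore does not establish an effect of this change on either core.

The compounds shown leave open whether another group on the same aromatic carbon, such as an amine, a carboxylic acid or a methoxy group, would move the number beyond the scatter. Compound 1 and compound 3 also differ in more than one place, so the ester chains and the chloro on the core cannot be read apart.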